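Shortening the ester chain of a catechol ester

The source may report more compounds than this note shows. Statements on the series, on what has been measured and on what is new or still open speak of the compounds shown alone.

Compound 1 `CCCCCCCCCC(=O)OCCc1ccc(O)c(O)c1` gives 71100 nM in a toxicity assay on MRC5 cells (Homo sapiens) for inhibition, read by MTT assay, with a stated time of 72 h; a higher number here means a weaker inhibitor, a lower number a stronger inhibitor.
Compound 2 `CCCCCCCCCCCCCC(=O)OCCc1ccc(O)c(O)c1` is reported only as a limit of this assay, > 50000 nM, not as a number.
Compound 3 `CCCCCCCCCC(=O)OCCc1ccc(O)cc1` gives 172000 nM in this assay.

Compound 1 has the lowest of the two numbers shown; its nearest neighbour is compound 3, and the step of a 2.4-fold higher number from compound 1 to compound 3 (0.38 log units; beyond the scatter) is modest but beyond the scatter. The step that the limit leaves unreadable from compound 1 to compound 2 cannot be read because compound 2 sits at the limit (the limit of > 50000 nM in this assay, at which 1 of the 3 values shown sits).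

Compound 4 `CCCC(=O)OCCc1ccc(O)c(O)c1` differs from compound 1 by hydrogen in place of hexyl on a saturated chain carbon, three bonds along the chain from a carbonyl carbon. The same kind of change, cut one bond further out, reads heptyl to methyl. Neither measured step alters the ester chain at this place: one removes a hydroxy on the aromatic ring, the other lengthens the chain but ends at a limit. The change in compound 4 is therefore untested by the numbers shown, and any expectation rests on the size of the change alone. A modest shift toward a higher number is expected, as a 2.1-fold higher number from compound 1 to compound 4 (0.32 log units; beyond the scatter). Compound 4 is estimated at 150000 nM, between 60000 nM and 400000 nM.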

Compound 4, half-maximal inhibitory concentration: 71500 nM
For compound 4 the middle estimate is 2.1-fold (0.32 log units) above the measured one, and the stated range covers the measured number.
By their numbers in this assay, from the lowest: compounds 1 and 4 (each within the scatter of the next); then compound 3.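

Taking hexyl off the chain and leaving hydrogen, at the place three bonds along from the carbonyl carbon, gives a 1.0-fold higher number from compound 1 to compound 4 (0.00 log units; within the scatter) in this assay. Among the compounds with a readable number, this is the first test of the ester chain itself, and these two compounds cannot be told apart, even though one carries a much shorter chain. Among these compounds, the only readable step beyond the scatter remains the one on the aromatic carbon, a 2.4-fold higher number from compound 1 to compound 3 (0.38 log units; beyond the scatter). Compound 2 is reported only as a limit, so its step cannot be read and the longer chain stays undecided: the limit of > 50000 nM in this assay, at which 1 of the 4 values shown sits.

As far as these compounds go, whether the chain would tolerate an amine or a carboxylic acid at its end remains open. So does the question of whether swapping the ester for an amide would leave the number in the same place.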